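Amine substituent variation on the diaryl ether series

A few compounds are considered here, and "the series" means these few. Any claim that something is new, unique, unknown or untested is made for them only; others in the source may bear on it.

Compound 1 `CCN1CCN(Cc2c(OC)cc(Oc3cccc(Nc4ccccc4)c3)cc2OC)CC1` — in a functional assay on HCT-116 cells (Homo sapiens) for inhibition, read by MTT assay, with a stated time of 72 h (on this read-out higher numbers stand for weaker inhibition and lower numbers for stronger inhibition), compound 1 gives > 20000 nM, which is a limit of the assay.
Compound 2 `COc1cc(Oc2cccc(Nc3ccccc3)c2)cc(OC)c1CNC(C)C` — in this assay compound 2 gives > 20000 nM, again a limit.
Compound 3 `COc1cc(Oc2cccc(Nc3ccccc3)c2)cc(OC)c1CNC1CC1` — in this assay compound 3 gives > 20000 nM, also a limit.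

Compound 3 thus stands at the limit with the other two; no number separates them. The steps a step that the two limits leave unreadable from compound 1 to compound 2, a step that the two limits leave unreadable from compound 1 to compound 3 and a step that the two limits leave unreadable from compound 2 to compound 3 are all unreadable, as both ends sit at the limit (the limit of > 20000 nM in this assay, at which 3 of the 3 values shown sit).

Compound 4 `COc1cc(Oc2cccc(Nc3ccccc3)c2)cc(OC)c1CNCc1ccc(Br)cc1` differs from compound 3 by 4-bromobenzyl in place of cyclopropyl on an amine nitrogen. The closest measured step, from compound 2 to compound 3, also changes the group on that amine nitrogen, yet its size cannot be read, because both values sit at the limit (the limit of > 20000 nM in this assay, at which 3 of the 3 values shown sit). Among the compounds with values here, no measured step therefore gives a direction or size for this change.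

Compound 4 is expected to remain near the limit, with the step that the limit leaves unreadable from compound 3 to compound 4 estimated as no readable change. The estimate for compound 4 in this assay is 25000 nM, with a range from 6000 nM to 80000 nM, and most likely only a limit will be reported again.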

Compound 4, half-maximal inhibitory concentration: 6230 nM
The estimate for compound 4 lay 4.0-fold (0.60 log units) above the measured number, and the stated range covers the measured number.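

The amine nitrogen on the saturated chain carbon now gives the first readable move in the series in this assay: 4-bromobenzyl in place of cyclopropyl gives an at least 3.2-fold lower number from compound 3 to compound 4 (0.50 log units; beyond the scatter), and 4-bromobenzyl in place of isopropyl gives an at least 3.2-fold lower number from compound 2 to compound 4 (0.50 log units; beyond the scatter). Replacing the whole amine, with (4-bromobenzyl)amino in place of 4-ethylpiperazin-1-yl, gives an at least 3.2-fold lower number from compound 1 to compound 4 (0.50 log units; beyond the scatter), so an entering group of 8 heavy atoms with a six-membered aromatic ring separates compound 4 from all three earlier amines, whether these are open-chain, cyclopropyl or piperazine. Each of these steps starts from a limit and fixes only a least size, and the steps among compounds 1, 2 and 3 remain unreadable: the limit of > 20000 nM in this assay, at which 3 of the 4 values shown sit.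

Compound 4 is the only compound shown with an aromatic ring on this nitrogen, and the bromine and the benzyl ring arrive together, leaving their shares of the step unresolved; an unsubstituted benzyl or a 4-chlorobenzyl on the same nitrogen would separate them. From the compounds shown here alone, the length of the link to the ring also remains open, and a 2-phenylethyl group in the same place would address it.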